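A few compounds are considered here, and "the series" means these few. Any claim that something is new, unique, unknown or untested is made for them only; others in the source may bear on it.

Values in a functional assay on A2780 cells (Homo sapiens) for inhibition, read by WST assay, with a stated time of 72 h; on this read-out lower numbers stand for stronger inhibition and higher numbers for weaker inhibition:
- compound 1 `N#C/N=C(\NCCCCCCC(=O)NOC1CCCCC1)Nc1ccncc1`: 35 nM
- compound 2 `N#C/N=C(\NCCCCCCC(=O)N(Cc1ccccc1)OC1CCCCC1)Nc1ccncc1`: 0.055 nM
- compound 3 `C[C@H](CCCCCN/C(=N\C#N)Nc1ccncc1)C(=O)NOC1CCCCC1`: 3.9 nM

Compound 1 stands highest of the three, so it is the weakest inhibitor here. Compound 4 `N#C/N=C(\NCCCCC[C@@H](Cc1ccccc1)C(=O)NOC1CCCCC1)Nc1ccncc1` is still unmeasured. Its change from compound 1 is benzyl in place of hydrogen on a saturated chain carbon bound to a carbonyl carbon and a saturated chain carbon. Going by the values given here, two measured steps bear on it. Methyl on that same saturated chain carbon gave a 9.0-fold lower number from compound 1 to compound 3 (0.95 log units; beyond the scatter). Benzyl on an amide-type nitrogen gave a 640-fold lower number from compound 1 to compound 2 (2.80 log units; beyond the scatter), so it is the same group at a different place. The carbon precedent carries more weight, and the nitrogen step leaves room for a larger effect. A lower number is expected in this assay, with the step nearer the methyl one. The estimated change is an 18-fold lower number from compound 1 to compound 4 (1.24 log units; beyond the scatter). For compound 4 the expected value is 2 nM, within an estimated range of 0.2 nM to 20 nM.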

Compound 4, half-maximal inhibitory concentration: 0.32 nM
Compound 4: the middle estimate sits 6.3-fold (0.80 log units) above what was measured, within the range that was stated.
By their numbers in this assay, from the lowest: compound 2; then compound 4; then compound 3; then compound 1.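

In this assay, benzyl on the saturated chain carbon bound to a carbonyl carbon and a saturated chain carbon gives a 110-fold lower number from compound 1 to compound 4 (2.04 log units; beyond the scatter). Phenyl in place of hydrogen on the methyl of compound 3 adds a further step, a 12-fold lower number from compound 3 to compound 4 (1.09 log units; beyond the scatter), so this position is not exhausted by methyl. Nothing available explains this gain.

Still open, as far as these compounds go, is whether phenethyl, an amine or a carboxylic acid on this carbon would continue the trend. Also open, from the compounds shown here alone, is whether benzyl on this carbon and benzyl on the amide-type nitrogen would combine.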